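Swapping a Sulfonamide Aryl Group for a Small Ester

This account rests on a few compounds, and the source may have more. Where it says the series, first, only, none or still open, it means among the compounds named here.

Measured so far:
Compound 1, `CCCCCCCCc1ccc(OCC(=O)Cn2nnc(-c3ccc(S(=O)(=O)N(C)C)cc3)n2)cc1`: 590 nM
Compound 2, `CCCCCCCCc1ccc(OCC(=O)Cn2nnc(Cc3ccccc3)n2)cc1`: 66 nM

In an assay on microsomes from brain for inhibition of Fatty-acid amide hydrolase 1 (Rattus norvegicus), read by fluorescence and HPLC, with a stated time of 60 min (on this read-out higher numbers stand for weaker inhibition and lower numbers for stronger inhibition), compound 1 gives 590 nM, the highest of the two numbers; its nearest neighbour is compound 2 at 66 nM, and the step of an 8.9-fold lower number from compound 1 to compound 2 (0.95 log units; beyond the scatter) shows that a benzyl in place of 4-(dimethylsulfamoyl)phenyl on an aromatic carbon brings a clearly stronger inhibition. Compound 3, `CCCCCCCCc1ccc(OCC(=O)Cn2nnc(C(=O)OC)n2)cc1`, alters the same aromatic carbon of compound 1, but differently: methoxycarbonyl in place of 4-(dimethylsulfamoyl)phenyl on an aromatic carbon. Going by the values given here, the only measured step, an 8.9-fold lower number from compound 1 to compound 2 (0.95 log units; beyond the scatter), concerns a different incoming group, so it bears on this change only loosely: it indicates that the 4-(dimethylsulfamoyl)phenyl group is not needed for a low number, but says nothing about a methoxycarbonyl there. For compound 3 the expected step is estimated as a 2.0-fold lower number from compound 1 to compound 3 (0.29 log units; within the scatter), with wide uncertainty around it. Compound 3 is therefore estimated at 300 nM, within 60 nM to 1500 nM.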

Compound 3, half-maximal inhibitory concentration: 88 nM
Compound 3: the middle estimate sits 3.4-fold (0.53 log units) above what was measured; the measured number falls inside the stated range.
By their numbers in this assay, from the lowest: compounds 2 and 3 (each within the scatter of the next); then compound 1.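

In this assay, replacing the 4-(dimethylsulfamoyl)phenyl group with methoxycarbonyl gives a 6.7-fold lower number from compound 1 to compound 3 (0.83 log units; beyond the scatter), so a low number at this carbon of the five-membered ring does not require an incoming group with a six-membered aromatic ring: methoxycarbonyl has no ring and only 4 heavy atoms. Exchanging benzyl for methoxycarbonyl gives a 1.3-fold higher number from compound 2 to compound 3 (0.12 log units; within the scatter), so this assay does not separate these two quite different groups. Nothing shown here explains how either group relates to the number obtained.

From the compounds shown here alone, it remains open whether a plain phenyl group at this carbon would give a number close to that of compound 1 or closer to those of compound 2 and compound 3. A carboxylic acid or a primary amide in place of the methoxycarbonyl also remains untested among the compounds shown.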